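The source may hold more compounds than are shown below. What is called first, only, known or untested is meant among the compounds shown, and "the series" means these compounds.

Compound 1 `COc1cc(COCc2cn(Cc3cc(-c4ccc(F)cc4)cnc3Cl)nn2)cc(OC)c1OC`: 96600 nM
Compound 2 `COc1cc(COCc2cn(Cc3cc(-c4ccc(C)cc4)cnc3Cl)nn2)cc(OC)c1OC`: 146000 nM

In a functional assay on MCF7 cells (Homo sapiens) for cytotoxicity, read by MTT assay, with a stated time of 48 h (on this read-out higher numbers stand for weaker inhibition and lower numbers for stronger inhibition), compound 2 gives 146000 nM, which lies within the scatter of compound 1 at 96600 nM. Compound 3 `COc1cc(COCc2cn(Cc3cc(-c4ccccc4)cnc3Cl)nn2)cc(OC)c1OC` differs from compound 2 by hydrogen in place of methyl on an aromatic carbon. Among the compounds with values here, one measured step bears on this change, also at that methyl: a 1.5-fold higher number from compound 1 to compound 2 (0.18 log units; within the scatter). With methyl in place of fluoro, that step stayed within the scatter, so no step beyond the scatter is expected in this assay, and no direction can be relied on. The estimated change is a 1.3-fold lower number from compound 2 to compound 3 (0.10 log units; within the scatter). Compound 3 is expected at about 115000 nM, with an estimated range of 60000 nM to 220000 nM.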

Compound 3, half-maximal inhibitory concentration: 86700 nM
The estimate for compound 3 lay 1.3-fold (0.12 log units) above the measured number; the measured number falls inside the stated range.
By their numbers in this assay, from the lowest: compounds 3, 1 and 2 (each within the scatter of the next).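

With hydrogen at this position, para to a large group, the number in this assay stays within the scatter of both substituted compounds: hydrogen in place of methyl gives (a 1.7-fold lower number from compound 2 to compound 3 (0.23 log units; within the scatter)) and hydrogen in place of fluoro gives (a 1.1-fold lower number from compound 1 to compound 3 (0.05 log units; within the scatter)). Fluoro, methyl and hydrogen at this position therefore cannot be told apart in this read-out, and neither substituent separates from the phenyl compound. No evidence is available to explain this result.

From the compounds shown here alone, whether an amine, a carboxylic acid or a longer chain at this position would give a step beyond the scatter stays open.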